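Trading a tert-butylphenyl for a methylindolyl on the shared core

The compounds below may be only part of what the source reports. "The series", "measured", "known", "first", "only" and "open" are said of these compounds alone.

The account starts from compound 1, `COc1cc(-c2ccnc3cc(-c4ccc(C(C)(C)C)cc4)nn23)cc(OC)c1OC`, whose trimethoxyphenyl-bearing core carries a 4-(tert-butyl)phenyl group. In a functional assay on B16-F0 cells (Mus musculus) for inhibition, read by CCK-8 assay, with a stated time of 48 h (a lower number here means a stronger inhibitor, a higher number a weaker inhibitor), compound 1 gives only a limit, > 10000 nM, so no number is known for it; this is the limit marked by the limit of > 10000 nM in this assay, at which 1 of the 2 values shown sits.

Among the measured compounds shown here, the one measured neighbour is compound 2, `COc1cc(-c2ccnc3cc(-c4ccc(-c5cnn(C)c5)cc4)nn23)cc(OC)c1OC`, in which 1-methyl-1H-pyrazol-4-yl replaces tert-butyl. In this assay compound 2 gives 1240 nM, a step of an at least 8.0-fold lower number from compound 1 to compound 2 (0.90 log units; beyond the scatter), so a nitrogen heterocycle in place of the tert-butyl group brought the number down to a measurable value.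

Compound 3, `COc1cc(-c2ccnc3cc(-c4ccc5c(ccn5C)c4)nn23)cc(OC)c1OC`, is not yet measured. It differs from compound 1 by 1-methyl-1H-indol-5-yl in place of 4-(tert-butyl)phenyl on an aromatic carbon. This change also removes the tert-butyl group and brings in a ring nitrogen, so the step from compound 1 to compound 2 bears on it, though only loosely, as the whole aryl group is exchanged rather than one substituent.

Compound 3 is therefore expected to show an at least 2.8-fold lower number from compound 1 to compound 3 (0.45 log units; beyond the scatter) in this assay. The estimated value for compound 3 is 3500 nM, with a range from 900 nM to 12000 nM.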

Compound 3, half-maximal inhibitory concentration: 48 nM
Beside the measured number, compound 3's estimate is 73-fold (1.86 log units) above it; the whole stated range lies above it.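

In this assay, the exchange at this aromatic carbon of the five-membered aromatic ring with 2 nitrogen gives an at least 200-fold lower number from compound 1 to compound 3 (2.31 log units; beyond the scatter), which shows that replacing the whole aryl group, and not just its substituent, can produce a large step here. Among the compounds that replace the 4-(tert-butyl)phenyl group or its tert-butyl substituent, compound 2 gives 1240 nM, while compound 3 gives 48 nM, so the printed values now reach well below the level seen with the earlier neighbour. The true size of the step from the starting compound stays open, because compound 1 carries a limit of the assay and not a number: the limit of > 10000 nM in this assay, at which 1 of the 3 values shown sits.

The ring nitrogen and the fused five-membered aromatic ring enter together in compound 3, and the compounds shown do not separate what each contributes. They also leave open whether 1H-indol-5-yl without the methyl group, an ethyl chain in place of that methyl, or an amine or a carboxylic acid on the six-membered ring would hold the value of compound 3.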